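Pyrimidinyl thiourea series: growth inhibition of Brassica napus

This account rests on a few compounds, and the source may have more. Where it says the series, first, only, none or still open, it means among the compounds named here.

compound 1 `COc1cc(SC)nc(NC(=S)NC(=O)c2c(-c3ccc(Cl)cc3Cl)noc2C)n1` — in a functional assay on the whole organism for inhibition, with Brassica napus as the target, with a stated time of 72 h, tested at 100 mg/L (a higher number here means more inhibition of growth at the concentration tested, a lower number less inhibition of growth), compound 1 gives 69.2%
compound 2 `COc1cc(SC)nc2n/c(=N/C(=O)c3c(-c4ccc(Cl)cc4Cl)noc3C)sn12` — compound 2 gives 75.8%
compound 3 `COc1cc(OC)n2s/c(=N\C(=O)c3c(-c4ccc(Cl)cc4Cl)noc3C)nc2n1` — compound 3 gives 85.6%

Compound 1 stands lowest of the three numbers; its nearest neighbour is compound 2, within the scatter, while compound 3 lies beyond the scatter above it. For the measured compounds named here, the only measured one-place step, a number 9.8 percentage points higher from compound 2 to compound 3 (within the scatter), concerns an exchange on an aromatic carbon of the core and does not touch the ring replacement considered here. Compound 4 `Cc1cc(Cl)nc(NC(=S)NC(=O)c2c(-c3ccc(Cl)cc3Cl)noc2C)n1` differs from compound 1 by 4-chloro-6-methylpyrimidin-2-yl in place of 4-methoxy-6-(methylsulfanyl)pyrimidin-2-yl on an amide-type nitrogen. Going by the values given here, no measured step bears on this exchange, so there is no basis for a step beyond the scatter in either direction, and the estimate stays close to compound 1 with a wide range. Compound 4 is expected to give 64%, between 42% and 84%, an expected step of a number 5.2 percentage points lower from compound 1 to compound 4 (within the scatter).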

Compound 4, percent growth inhibition at one concentration: 50.8%
Compound 4: middle estimate off by 13.2 percentage points, on the high side; the range from low to high includes it.
By their numbers in this assay, from the lowest: compound 4; then compounds 1, 2 and 3 (each within the scatter of the next, the first and the last beyond it).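

In this assay, 4-chloro-6-methylpyrimidin-2-yl in place of 4-methoxy-6-(methylsulfanyl)pyrimidin-2-yl on the amide-type nitrogen gives a number 18.4 percentage points lower from compound 1 to compound 4 (beyond the scatter) and so shows that growth inhibition in this thiourea depends on the pyrimidinyl substituent. For the compounds shown here, this is the first step that touches this position, and it is large enough to read. Nothing measured here accounts for the drop.

Going by these compounds, both substituents on the pyrimidine change at once, and which exchange carries the step stays open. On these data alone, how an amine or an ethoxy group on the pyrimidine would fare also remains open.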